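The compounds below may be only part of what the source reports. "The series", "measured", "known", "first", "only" and "open" are said of these compounds alone.

Going by the values given here, compound 3 `Cc1ccc(OCC(=O)N(Cc2cccs2)c2cnccn2)cc1` stands at the top of the three numbers measured so far: in an assay on HEK293 cells for agonist activity at transient receptor potential cation channel subfamily M member 8 (Homo sapiens), read by fluorescence and calcium flux, with a stated time of 15 min (a higher number here means that more compound is needed for the effect, a lower number that less compound is needed), compound 3 gives 1240 nM. Its nearest neighbour is compound 2 `Cc1ccc(OCC(=O)N(Cc2cccs2)C(C)C)cc1`, which in this assay gives 70 nM, and furthest away is compound 1 `Cc1ccc(OCC(=O)N(Cc2cccs2)c2ccccc2)cc1`, which gives 23 nM. Both measured steps into compound 3 are large: a 54-fold higher number from compound 1 to compound 3 (1.73 log units; beyond the scatter) and an 18-fold higher number from compound 2 to compound 3 (1.25 log units; beyond the scatter), while the step between the other two is modest, a 3.0-fold higher number from compound 1 to compound 2 (0.48 log units; beyond the scatter).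

Compound 4 `Cc1ccc(OCC(=O)N(Cc2cccs2)C(C)(C)C)cc1` differs from compound 3 in one place: tert-butyl in place of pyrazin-2-yl on an amide-type nitrogen. Among the compounds with values here, of the measured steps, the one from compound 2 to compound 3 bears most directly on this change, since isopropyl and tert-butyl are both saturated carbon groups without a ring, and that step was large. Running it in reverse, a large drop in the number is expected when pyrazin-2-yl gives way to tert-butyl, with the step from compound 1 to compound 2 hinting that a branched group may not quite reach the number of compound 1. The expected step is therefore a 12-fold lower number from compound 3 to compound 4 (1.09 log units; beyond the scatter). In this assay compound 4 is estimated at 100 nM, most likely between 30 nM and 400 nM.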

Compound 4, half-maximal effective concentration: 11000 nM
Beside the measured number, compound 4's estimate is 110-fold (2.04 log units) below it; measured number above the stated range.
By their numbers in this assay, from the lowest: compound 1; then compound 2; then compound 3; then compound 4.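

At this place on the amide-type nitrogen, in this assay, a branched saturated carbon group does not by itself keep the number low: methyl in place of hydrogen on the saturated chain carbon bound to that nitrogen gives a 160-fold higher number from compound 2 to compound 4 (2.20 log units; beyond the scatter) and so turns one of the lower numbers into the highest of the four. Tert-butyl also ends above the ring-bearing pyrazin-2-yl, with an 8.9-fold higher number from compound 3 to compound 4 (0.95 log units; beyond the scatter), and far above phenyl, with a 480-fold higher number from compound 1 to compound 4 (2.68 log units; beyond the scatter), so the two groups without a ring fall on either side of pyrazin-2-yl and the presence of a ring does not sort these four compounds. Nothing available explains why this one added methyl separates compound 2 and compound 4 so widely.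

The compounds shown leave open where a straight chain such as ethyl or n-propyl, or a saturated ring such as cyclopropyl or cyclohexyl, would fall at this place. They also leave open whether a phenyl carrying a fluorine or a methoxy group would stay close to compound 1 or move towards the higher numbers of compound 3 and compound 4.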